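Adding a Methyl to the Hydroxy Oxygen of Compound 1

The source may report more compounds than this note shows. Statements on the series, on what has been measured and on what is new or still open speak of the compounds shown alone.

In a functional assay on SR cells (Homo sapiens) for antiproliferative activity, read by sulforhodamine B assay, with a stated time of 48 h (on this read-out higher numbers stand for weaker inhibition and lower numbers for stronger inhibition), compound 1 `O=C(NCCCNc1cc(-c2cn(-c3ccccc3)nc2-c2cccc(O)c2)ccn1)Nc1ccc(F)cc1` gives 1510 nM and compound 2 `O=C(NCCCNc1cc(-c2cn(-c3ccccc3)nc2-c2cccc(O)c2)ccn1)Nc1cccc(C(F)(F)F)c1` gives 1650 nM, so the two stand within the scatter of each other. That one measured step, a 1.1-fold higher number from compound 1 to compound 2 (0.04 log units; within the scatter), puts 3-(trifluoromethyl)phenyl in place of 4-fluorophenyl on an amide-type nitrogen. It leaves the hydroxy group untouched and so bears only indirectly on what follows.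

Compound 3 `COc1cccc(-c2nn(-c3ccccc3)cc2-c2ccnc(NCCCNC(=O)Nc3ccc(F)cc3)c2)c1` turns 3-hydroxyphenyl into 3-methoxyphenyl, with methyl in place of hydrogen on an oxygen on an aromatic ring. Within the data shown here, no measured pair tests this change, so its size is unknown. Starting from compound 1 at 1510 nM, a modest move towards a higher number is expected in this assay, though the opposite direction cannot be excluded. The estimated change is a 1.6-fold higher number from compound 1 to compound 3 (0.20 log units; within the scatter). For compound 3 the expected value is 2400 nM, with an estimated range of 1000 nM to 6000 nM.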

Compound 3, half-maximal inhibitory concentration: 7700 nM
For compound 3 the middle estimate is 3.2-fold (0.51 log units) below the measured one; measured number above the stated range.
By their numbers in this assay, from the lowest: compounds 1 and 2 (each within the scatter of the next); then compound 3.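

Methyl in place of hydrogen on an oxygen on an aromatic ring gives a 5.1-fold higher number from compound 1 to compound 3 (0.71 log units; beyond the scatter) in this assay and so marks the hydroxy oxygen as a place where a single added carbon moves the number towards weaker inhibition. The one earlier step, on the amide-type nitrogen, stayed within the scatter, so this is the first change among these compounds that clearly separates two of them. Nothing measured here accounts for the shift.

Still open, on these data alone, is whether the hydrogen of the hydroxy group is what counts, and how an amino group or an ethoxy group would read in the same place. Also open, as far as these compounds go, is whether the same methyl would have a step of similar size when the 3-(trifluoromethyl)phenyl group of compound 2 is present.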